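The source may report more compounds than this note shows. Statements on the series, on what has been measured and on what is new or still open speak of the compounds shown alone.

In a functional assay on KB cells (Homo sapiens) for cytotoxicity, read by MTT assay, with a stated time of 72 h (on this read-out lower numbers stand for stronger inhibition and higher numbers for weaker inhibition), compound 1, `COc1ccc(Nc2nc3ccccc3nc2S(=O)(=O)c2ccc(C)cc2)cc1`, has no number, and its entry reads "not determined" (no result reported). Compound 2, `Cc1ccc(S(=O)(=O)c2nc3ccccc3nc2Nc2ccc(N)cc2)cc1`, gives 5630 nM. For the measured compounds named here, that is the only measured value in this assay, so compound 2 cannot yet be ranked against anything. Compound 3, `Cc1ccc(S(=O)(=O)c2nc3ccccc3nc2Nc2ccc(C(F)(F)F)cc2)cc1`, differs from compound 2 in one place: trifluoromethyl in place of amino on an aromatic carbon. Here trifluoromethyl stands in place of amino on an aromatic carbon, para to a large group. Going by the values given here, no measured step shows what such a swap does in this assay. Among the compounds with values here, the only anchor is compound 2 at 5630 nM, so the expectation stays close to that value: a small shift towards stronger inhibition, possibly none beyond the scatter. The estimated step is a 1.4-fold lower number from compound 2 to compound 3 (0.15 log units; within the scatter). Compound 3 is expected to read 4000 nM, with an estimated range from 1200 nM to 15000 nM.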

Compound 3, half-maximal inhibitory concentration: 10300 nM
Compound 3: the middle estimate sits 2.6-fold (0.41 log units) below what was measured; low and high end bracket the measured number.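

In this assay, for the compounds shown here, the exchange of amino for trifluoromethyl on the aromatic carbon gives a 1.8-fold higher number from compound 2 to compound 3 (0.26 log units; within the scatter) and so provides the first measured step at this position, one that does not separate the two compounds. On this single pair, a group with a hydrogen-bond donor and acceptor and a larger group with neither give readings that lie within the usual scatter of each other. Nothing measured here bears on the reason for this result.

Going by these compounds alone, compound 1 has the entry "not determined" (no result reported) and offers no number, so no step to it can be read. On these data alone, it remains open how a carboxylic acid or a nitrile would read in the same place, and whether any group there would shift the number beyond the scatter.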